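The compounds below may be only part of what the source reports. "The series", "measured", "known", "first", "only" and "open" are said of these compounds alone.

Going by the values given here, compound 2 `COc1ccc(/C=C/C(=N\O)c2ccc(OC)cc2)cc1` gives 2170000 nM in an ADME assay on cells (Mus musculus, strain Balb/c) for cytotoxicity, read by MTT assay, with a stated time of 48 h (on this read-out lower numbers stand for higher toxicity in this test and higher numbers for lower toxicity in this test), the higher of the two numbers so far; compound 1 `COc1ccc(C(/C=C/c2ccc(Br)cc2)=N/O)cc1` gives 737000 nM in this assay. Among the compounds with values here, the one step measured, a 2.9-fold higher number from compound 1 to compound 2 (0.47 log units; beyond the scatter), introduced methoxy in place of bromo. Compound 3 `COc1ccc(/C=C/C(=N\O)c2ccc(Br)cc2)cc1` reverses that exchange, though on the other ring: bromo in place of methoxy on an aromatic carbon. Since the same swap in the other direction gave a 2.9-fold higher number from compound 1 to compound 2 (0.47 log units; beyond the scatter), a step of similar size back toward the lower number is expected for compound 3, namely a 2.5-fold lower number from compound 2 to compound 3 (0.40 log units; beyond the scatter). Compound 3 is therefore estimated at 870000 nM, within a range of 400000 nM to 2000000 nM.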

Compound 3, half-maximal cytotoxic concentration: 23700 nM
Estimate against measurement, compound 3: 37-fold (1.56 log units) above, and the stated range ends above it.
By their numbers in this assay, from the lowest: compound 3; then compound 1; then compound 2.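

Placed on this ring, bromo in place of methoxy gives a 92-fold lower number from compound 2 to compound 3 (1.96 log units; beyond the scatter) in this assay, so this position responds far more strongly to the exchange than the other ring did. There, the reverse exchange gave a 2.9-fold higher number from compound 1 to compound 2 (0.47 log units; beyond the scatter), so in both steps the bromo compound carries the lower number, but the size depends heavily on the ring. No available evidence accounts for this difference.

From the compounds shown here alone, whether an amine, a carboxylic acid or a longer chain at this position would give a low or high number remains open. So does the result of bromo on both rings.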